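Trifluoromethyl Swap on the Furan Analogue: Expected Inhibition

The compounds below may be only part of what the source reports. "The series", "measured", "known", "first", "only" and "open" are said of these compounds alone.

Compound 2 `CC1=C(C(=O)OCC(F)(F)F)C(c2cccs2)NC(=O)N1` and compound 1 `CC1=C(C(=O)OC(C(F)(F)F)C(F)(F)F)C(c2cccs2)NC(=O)N1` share a core. In an assay on HeLa cells for displacement of a labelled ligand from adenosine receptor A3 (Homo sapiens), read by radioligand binding, with a stated time of 180 min, tested at 1 uM (on this read-out lower numbers stand for less inhibition and higher numbers for more inhibition at the one concentration tested (going by the name of the read-out)), compound 2 gives 1%, and compound 1 gives 1%. The change between them is trifluoromethyl in place of hydrogen on a saturated chain carbon bound to an oxygen next to a carbonyl group and a saturated chain carbon, and the step it made was no change at the digits printed from compound 2 to compound 1 (within the scatter). Compound 3 `CC1=C(C(=O)OCC(F)(F)F)C(c2ccco2)NC(=O)N1` differs from compound 2 in its core by furan-2-yl in place of thiophen-2-yl on a saturated ring carbon; in this assay compound 3 gives 1%, a step of no change at the digits printed from compound 2 to compound 3 (within the scatter). Compound 4 `CC1=C(C(=O)OC(C(F)(F)F)C(F)(F)F)C(c2ccco2)NC(=O)N1` has not yet been measured and carries the same change on the core of compound 3, namely (trifluoromethyl in place of hydrogen on a saturated chain carbon bound to an oxygen next to a carbonyl group and a saturated chain carbon), at the same place. The step from compound 3 to compound 4 is expected to be no change at the digits printed from compound 3 to compound 4 (within the scatter), because the same change earlier gave no change at the digits printed from compound 2 to compound 1 (within the scatter). Compound 4 is therefore estimated at 1%, with a likely range from -5% to 10%.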

Compound 4, a percentage reported as inhibition, at one concentration (the size of the read-out at that concentration, not a potency): 2%
The estimate for compound 4 lay 1 percentage points below the measured number; low and high end bracket the measured number.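

In this assay, adding the trifluoromethyl group gives a number 1 percentage points higher from compound 3 to compound 4 (within the scatter), and this step agrees with the one on the other core: the same change on two cores in this assay, no change at the digits printed (within the scatter) from compound 2 to compound 1 and a number 1 percentage points higher (within the scatter) from compound 3 to compound 4, 1 percentage points apart, within the scatter of two such steps. Swapping thiophen-2-yl for furan-2-yl gives a number 1 percentage points higher from compound 1 to compound 4 (within the scatter), and this step also agrees with its earlier counterpart: the same change on two cores in this assay, no change at the digits printed (within the scatter) from compound 2 to compound 3 and a number 1 percentage points higher (within the scatter) from compound 1 to compound 4, 1 percentage points apart, within the scatter of two such steps. Both changes therefore carried from one core to the other without a visible difference, but all the compounds show almost no inhibition at the one concentration tested, so this does not show how either change would behave on a compound with clear inhibition.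

From the compounds shown here alone, it remains open whether a longer chain or an amine at the same place would give measurable inhibition. The same question applies to a carboxylic acid on the saturated ring carbon.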